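The source may hold more compounds than are shown below. What is called first, only, known or untested is meant among the compounds shown, and "the series" means these compounds.

Measured compounds in an ADME assay on LLC-MK2 cells (Macaca mulatta) for cytotoxicity, read by spectrophotometry and crystal violet staining, with a stated time of 4 days; a higher number here means that more compound is tolerated, a lower number that less compound is tolerated:

compound 1, `CC(C)n1ncc2c(C(=O)Nc3ccccc3F)cc(-c3cccnc3)nc21`: 50000 nM
compound 2, `CC(C)n1ncc2c(C(=O)Nc3cccc(F)c3F)cc(-c3cccs3)nc21`: 75000 nM
compound 3, `CC(C)n1ncc2c(C(=O)Nc3ccccn3)cc(C3CC3)nc21`: 25000 nM

Compound 2 gives the highest number of the three in this assay. Compound 1 stands nearest to it, within the scatter of repeated measurements, so no order between compound 2 and compound 1 can be claimed. Compound 3 stands furthest from compound 2, and that gap lies beyond the scatter. Among the compounds with values here, the measured compounds differ from one another in more than one place at once, so no step between them isolates the effect of a single change, and nothing in the numbers ties the group on the amide-type nitrogen to a move in this assay.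

Compound 4, `CC(C)n1ncc2c(C(=O)Nc3cccc(C(N)=O)c3)cc(-c3cccs3)nc21`, has not yet been measured in this assay. It differs from compound 2 in one place: 3-carbamoylphenyl in place of 2,3-difluorophenyl on an amide-type nitrogen. Within the data shown here, with no isolated step to lean on, the expected step of a 1.3-fold lower number from compound 2 to compound 4 (0.10 log units; within the scatter) is taken to be none beyond the scatter, in either direction. Compound 4 is therefore estimated at 60000 nM in this assay, with a range from 25000 nM to 150000 nM. Numbers of this size sit near the upper end of what such measurements usually resolve, so a limit rather than a number is possible.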

Compound 4, half-maximal cytotoxic concentration: 25000 nM
Estimate against measurement, compound 4: 2.4-fold (0.38 log units) above; measured number inside the range.
By their numbers in this assay, from the lowest: compounds 3, 4, 1 and 2 (each within the scatter of the next, the first and the last beyond it).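

In this assay the group on the amide-type nitrogen now has a readable effect of its own: 3-carbamoylphenyl in place of 2,3-difluorophenyl, with the rest of the molecule held fixed, gives a 3.0-fold lower number from compound 2 to compound 4 (0.48 log units; beyond the scatter) and shows that this position is not silent in this assay. The entering group counts 1 hydrogen-bond donor and 1 hydrogen-bond acceptor, the leaving group counts 0 of each, and the fluorine atoms go in the same step, so this single step cannot assign the move to the arrival of the carbamoyl group or to the loss of fluorine. No measurement shown accounts for the step, which stands as an observation only.

Still open, from the compounds shown here alone, is whether an unsubstituted phenyl on the amide-type nitrogen would stay with the difluorinated group or fall with the carbamoyl one, and whether a carboxylic acid or an aminomethyl group in the place of the carbamoyl group would move the number further. Also open, going by these compounds, is whether the same exchange gives a step of similar size on the cores of compound 1 and compound 3, which carry other groups elsewhere.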